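The source may hold more compounds than are shown below. What is called first, only, known or untested is meant among the compounds shown, and "the series" means these compounds.

Measured so far in an ADME assay on L6 cells (Rattus norvegicus) for cytotoxicity, read by resazurin assay, with a stated time of 72 h; on this read-out lower numbers stand for stronger inhibition and higher numbers for weaker inhibition:
Compound 1 `CN1CCN(CC(=O)N2CCC3(N4CCCCC4)CC(c4ccccc4)C2C(c2ccccc2)C3)CC1` gives 177000 nM
Compound 2 `CN1CCN(CCC(=O)N2CCC3(N4CCCCC4)CC(c4ccccc4)C2C(c2ccccc2)C3)CC1` gives 120000 nM
Compound 3 `NC1CC2(N3CCCCC3)CC(c3ccccc3)C1C(c1ccccc1)C2` gives 35000 nM

Compound 2 lies close to compound 1, and the gap between them (a 1.5-fold lower number from compound 1 to compound 2 (0.17 log units; within the scatter)) is no real difference. Compound 3 shows a clearly lower number than compound 2 on these three values.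

The next compound, compound 4 `CN1CCN(CCC(=O)N2CCC3(N4CCCC4)CC(c4ccccc4)C2C(c2ccccc2)C3)CC1`, keeps everything in compound 2 except one group, with pyrrolidin-1-yl in place of piperidin-1-yl on a saturated ring carbon. Among the measured compounds shown here, the only measured step between two compounds that differ in one place (a 1.5-fold lower number from compound 1 to compound 2 (0.17 log units; within the scatter)) concerns a saturated chain carbon bound to a carbonyl carbon, so it does not touch this site. All three measured compounds carry piperidin-1-yl, so no measurement shows what this swap does. With no evidence for a shift in either direction, no step beyond the scatter is expected in this assay. The estimated change is small (a 1.1-fold lower number from compound 2 to compound 4 (0.04 log units; within the scatter)). Compound 4 is therefore expected at about 110000 nM, with an estimated range from 50000 nM to 220000 nM (an expectation, not a measurement).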

Compound 4, half-maximal inhibitory concentration: 75400 nM
Compound 4: the middle estimate sits 1.5-fold (0.16 log units) above what was measured, within the range that was stated.
By their numbers in this assay, from the lowest: compound 3; then compounds 4, 2 and 1 (each within the scatter of the next, the first and the last beyond it).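

Among the compounds shown here, this is the first comparison at this saturated ring carbon of the shared core. In this assay, putting pyrrolidin-1-yl, a five-membered ring, in place of piperidin-1-yl, a six-membered ring, gives a 1.6-fold lower number from compound 2 to compound 4 (0.20 log units; within the scatter), so with the rest of compound 2 kept, this swap produces no real difference on this read-out. No measured property of either group is available to interpret this result.

Still open, from the compounds shown here alone, is whether a different group on this carbon, such as morpholin-4-yl or an open-chain dimethylamino group, would shift the number beyond the scatter. Going by these compounds, it is also open whether the same ring swap would give a similarly small step with the 4-methylpiperazin-1-yl side chain of compound 1.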